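The source may hold more compounds than are shown below. What is called first, only, known or untested is meant among the compounds shown, and "the series" means these compounds.

Compound 1, `NC(=O)c1c(NC(=O)c2ccccc2F)sc2c1CCN(C(=O)Nc1ccccc1Cl)C2`, and compound 2, `NC(=O)c1c(NC(=O)c2ccc(C(F)(F)F)cc2)sc2c1CCN(C(=O)Nc1ccccc1Cl)C2`, share one core and differ only in the aryl group carried on the carbonyl carbon. In a functional assay on MKN-74 cells (Homo sapiens) for antiproliferative activity, with a stated time of 24 h (a lower number here means a stronger inhibitor, a higher number a weaker inhibitor), compound 1 gives 49600 nM. In this assay compound 2 gives 43900 nM. The change between them is 4-(trifluoromethyl)phenyl in place of 2-fluorophenyl on a carbonyl carbon, and the step it made, a 1.1-fold lower number from compound 1 to compound 2 (0.05 log units; within the scatter), tells nothing about a direction.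

Compound 3, `NC(=O)c1c(NC(=O)c2ccccc2F)sc2c1CCN(C(=S)Nc1cc(C(F)(F)F)cc(C(F)(F)F)c1)C2`, carries a different core; the difference between the two cores is not broken down here. In this assay compound 3 gives 13300 nM, the lowest of the three numbers, and its gap to compound 2 as well as to compound 1 is beyond the scatter.

Compound 4, `NC(=O)c1c(NC(=O)c2ccc(C(F)(F)F)cc2)sc2c1CCN(C(=S)Nc1cc(C(F)(F)F)cc(C(F)(F)F)c1)C2`, stands to compound 3 as compound 2 stands to compound 1: 4-(trifluoromethyl)phenyl in place of 2-fluorophenyl on a carbonyl carbon. The place is the same word for word in both pairs, so this is the same change on a different core. Since compound 1 and compound 2 show this change to be within the scatter, the step for compound 4 is expected to be small, about a 1.1-fold lower number from compound 3 to compound 4 (0.04 log units; within the scatter). Compound 4 is therefore estimated at 12000 nM, with a range from 6000 nM to 26000 nM that rests on the value of compound 3, 13300 nM, and on the pair already measured.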

Compound 4, half-maximal inhibitory concentration: 13800 nM
Compound 4: the middle estimate sits 1.2-fold (0.06 log units) below what was measured; the measured number falls inside the stated range.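

In this assay, 4-(trifluoromethyl)phenyl in place of 2-fluorophenyl on a carbonyl carbon gives a 1.0-fold higher number from compound 3 to compound 4 (0.02 log units; within the scatter), so the values of this pair cannot be told apart, just as those of compound 1 and compound 2 cannot, and the two steps agree: the same change on two cores in this assay, a 1.1-fold lower number (0.05 log units; within the scatter) from compound 1 to compound 2 and a 1.0-fold higher number (0.02 log units; within the scatter) from compound 3 to compound 4, 1.2-fold (0.07 log units) apart, within the scatter of two such steps. This shows that, across these two cores, the exchange of these two aryl groups carries over as a step too small to read, and the result on one core would have served as a fair guide to the result on the other. It does not show that the change has a direction or that it would stay this small on any further core, since two pairs on two cores are all that bear on it and neither step stands clear of the scatter.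

The compounds shown leave open whether any other group on this carbonyl carbon, such as a cyclohexyl group or a phenyl ring carrying a carboxylic acid or an amine, would give a step beyond the scatter. They also leave open which part of the difference between the two cores goes with the lower numbers of compound 3 and compound 4.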